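A few compounds are considered here, and "the series" means these few. Any claim that something is new, unique, unknown or untested is made for them only; others in the source may bear on it.

Measured so far in an ADME assay on Vero cells (Chlorocebus sabaeus) for cytotoxicity, with a stated time of 72 h; a higher number here means a weaker inhibitor, a lower number a stronger inhibitor:

Compound 1 `O=[N+]([O-])c1cn2c(n1)OC[C@@H](OCc1cnn(-c3ccccc3)n1)C2` gives > 128000 nM, which is a limit of this assay rather than a number.
Compound 2 `O=[N+]([O-])c1cn2c(n1)OC[C@@H](OCc1cnn(-c3ccc(C(F)(F)F)cc3)n1)C2` gives > 128000 nM, again a limit and not a number.
Compound 3 `O=[N+]([O-])c1cn2c(n1)OC[C@@H](OCc1nnn(-c3ccccc3)n1)C2` gives > 128000 nM, also a limit and not a number.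

Compound 2 arises from compound 1 by one change, (trifluoromethyl in place of hydrogen on an aromatic carbon). The step it made in this assay, a step that the two limits leave unreadable from compound 1 to compound 2, cannot be read, since both ends are limits. Compound 3 carries a different core; how it differs from the core of compound 1 is not broken down here.

The unmeasured compound 4 `O=[N+]([O-])c1cn2c(n1)OC[C@@H](OCc1nnn(-c3ccc(C(F)(F)F)cc3)n1)C2` stands to compound 3 as compound 2 stands to compound 1, with the same change, (trifluoromethyl in place of hydrogen on an aromatic carbon), at a place described in the same words. Among the measured compounds shown here, the only guide is that (the limit of > 128000 nM in this assay, at which 3 of the 3 values shown sit). On that ground the step from compound 3 to compound 4 is expected to be no more than a number no higher from compound 3 to compound 4 (the limit leaves the size open), remaining unreadable. Compound 4 is therefore estimated to give about 128000 nM, most likely reported only as a limit again, with a range from 64000 nM to 300000 nM.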

Compound 4, half-maximal inhibitory concentration: > 128000 nM
Compound 4 was reported as a limit (the forecaster's own chance of this, stated with the estimate: 85%); the middle value sits exactly at the limit.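

In this assay compound 4 gives > 128000 nM, a limit and not a number. Compound 3 also gives only a limit, so the step between compound 3 and compound 4 cannot be read, just as the earlier step between compound 1 and compound 2 could not. All four results agree: the limit of > 128000 nM in this assay, at which 4 of the 4 values shown sit.

The compounds shown leave open what the true half-maximal inhibitory concentration of each one is, and whether trifluoromethyl in place of hydrogen shifts it.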